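Swapping a flexible amide tail for a rigid one

The source may report more compounds than this note shows. Statements on the series, on what has been measured and on what is new or still open speak of the compounds shown alone.

Compound 1 `Cc1nc(-c2ccc(C(F)(F)F)cc2)sc1CNc1ccc(OCC(=O)O)cc1` gives 288 nM in a functional assay on CHO cells for agonist activity at Free fatty acid receptor 1 (Homo sapiens); a higher number here means that more compound is needed for the effect, a lower number that less compound is needed.
Compound 2 `Cc1nc(-c2ccc(C(F)(F)F)cc2)sc1CNc1ccc(CCC(=O)NC(C)C)cc1` gives 100 nM in this assay.

Among the measured compounds shown here, compound 2 holds the lower of these two numbers, and the only measured step, a 2.9-fold lower number from compound 1 to compound 2 (0.46 log units; beyond the scatter), separates it from compound 1. Compound 3 `Cc1nc(-c2ccc(C(F)(F)F)cc2)sc1CNc1ccc([C@H]2C[C@@H]2C(=O)NC2CCNC2)cc1` carries 2-((pyrrolidin-3-yl)carbamoyl)cyclopropyl in place of 2-(isopropylcarbamoyl)ethyl on an aromatic carbon. For the measured compounds named here, that single step bears on it only loosely: it shows that this position of the shared core accepts an altered tail, but the new tail has no measured counterpart, so its direction is uncertain. The expected step is a 1.2-fold higher number from compound 2 to compound 3 (0.08 log units; within the scatter). Compound 3 is therefore estimated at 120 nM, with a range from 35 nM to 400 nM.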

Compound 3, half-maximal effective concentration: 204 nM
The estimate for compound 3 lay 1.7-fold (0.23 log units) below the measured number, and the stated range covers the measured number.
By their numbers in this assay, from the lowest: compound 2; then compounds 3 and 1 (each within the scatter of the next).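

The larger 2-((pyrrolidin-3-yl)carbamoyl)cyclopropyl tail keeps agonist activity at this position, but the step of a 2.0-fold higher number from compound 2 to compound 3 (0.31 log units; beyond the scatter) shows that it does not match the simpler 2-(isopropylcarbamoyl)ethyl tail. The step of a 1.4-fold lower number from compound 1 to compound 3 (0.15 log units; within the scatter) leaves compound 3 indistinguishable from the compound bearing carboxymethoxy, although the two tails differ widely. No supporting evidence explains either step.

As far as these compounds go, the cyclopropyl and pyrrolidine rings enter together, so their separate contributions remain open. From the compounds shown here alone, how a longer chain or a piperidine amide would behave at this position also remains open.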